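Series notes: positional isomer of the nitrooxymethyl benzoate

A few compounds are considered here, and "the series" means these few. Any claim that something is new, unique, unknown or untested is made for them only; others in the source may bear on it.

The compounds share one core, carrying an acetylsalicylate on one side and a varying ester on the other. Compound 1 `CC(=O)Oc1ccccc1C(=O)O[C@H]1CO[C@H]2[C@@H]1OC[C@H]2OC(=O)c1ccccc1O` gives 0.0825 h in an ADME assay on a cell-free system (plasma, Homo sapiens) for metabolic stability, with Plasma (Rattus norvegicus) as the target, read by HPLC, at pH 7.4; a higher number here means that the compound lasts longer, a lower number that the compound disappears faster. Compound 2 `CC(=O)Oc1ccccc1C(=O)O[C@H]1CO[C@H]2[C@@H]1OC[C@H]2OC(=O)C1CC1` gives 0.0322 h in this assay, and compound 3 `CC(=O)Oc1ccccc1C(=O)O[C@H]1CO[C@H]2[C@@H]1OC[C@H]2OC(=O)c1cccc(CO[N+](=O)[O-])c1` gives 0.0433 h. Among the measured compounds shown here, compound 3 is not separated from compound 2 by more than the scatter, as a 1.3-fold higher number from compound 2 to compound 3 (0.13 log units; within the scatter) shows, nor from compound 1, as a 1.9-fold lower number from compound 1 to compound 3 (0.28 log units; within the scatter) shows; the only step beyond the scatter among the three is a 2.6-fold lower number from compound 1 to compound 2 (0.41 log units; beyond the scatter).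

Compound 4 `CC(=O)Oc1ccccc1C(=O)O[C@H]1CO[C@H]2[C@@H]1OC[C@H]2OC(=O)c1ccc(CO[N+](=O)[O-])cc1` differs from compound 3 by 4-((nitrooxy)methyl)phenyl in place of 3-((nitrooxy)methyl)phenyl on a carbonyl carbon. For the measured compounds named here, no measured step bears directly on this change: the three steps above all exchange the whole group on that carbonyl carbon, while here the same atoms are joined differently within one ring. Of the steps shown, the two that keep an aromatic ring in place, a 1.9-fold lower number from compound 1 to compound 3 (0.28 log units; within the scatter) and a 1.3-fold higher number from compound 2 to compound 3 (0.13 log units; within the scatter), both stay within the scatter, which argues against a large movement. Compound 4 is therefore expected to stay close to compound 3, with a 1.0-fold higher number from compound 3 to compound 4 (0.02 log units; within the scatter) as the expected step. The estimate for compound 4 in this assay is 0.045 h, with a range from 0.022 h to 0.09 h.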

Compound 4, half-life: 0.1 h
Compound 4: the middle estimate sits 2.2-fold (0.35 log units) below what was measured; the measured number lies above the stated range.
By their numbers in this assay, from the lowest: compounds 2, 3, 1 and 4 (each within the scatter of the next, the first and the last beyond it).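

In this assay the change from 3-((nitrooxy)methyl)phenyl to 4-((nitrooxy)methyl)phenyl on this carbonyl carbon gives a 2.3-fold higher number from compound 3 to compound 4 (0.36 log units; beyond the scatter) and so lies beyond the scatter, showing that the half-life at this position can respond to how the same atoms are joined within the ring, which the earlier exchanges of the whole group could not show. Compound 4 is also separated from the cyclopropyl ester by a 3.1-fold higher number from compound 2 to compound 4 (0.49 log units; beyond the scatter) where compound 3 was not, while a 1.2-fold higher number from compound 1 to compound 4 (0.08 log units; within the scatter) leaves compound 4 unseparated from the 2-hydroxyphenyl ester, so that two quite different aromatic groups give half-lives within the scatter of each other. No supporting data bear on why the arrangement within the ring matters here.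

On these data alone, whether this sensitivity persists with a longer chain carrying the nitrooxy group, as in 4-(2-(nitrooxy)ethyl)phenyl, or with an amine or a carboxylic acid on the ring in place of nitrooxymethyl, remains open. The half-life also does not tell which of the two ester groups on the shared core is lost first, so the step cannot yet be assigned to either ester.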